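Fluoro on compound 3: a step away from a limit

The compounds below may be only part of what the source reports. "The series", "measured", "known", "first", "only" and "open" are said of these compounds alone.

In a functional assay on A549 cells (Homo sapiens) for inhibition, read by sulforhodamine B assay, with a stated time of 48 h (on this read-out lower numbers stand for stronger inhibition and higher numbers for weaker inhibition), compound 1 (`COC(=O)[C@@]1(C)C[C@@H](c2coc3ccc(Br)cc3c2=O)N(c2ccccc2)O1`) gives 9900 nM. Compound 2 (`COC(=O)[C@H]1C[C@@H](c2coc3ccccc3c2=O)N(c2ccccc2)O1`) reads > 60000 nM, which is a limit of the assay. Compound 3 (`CCO[C@H]1C[C@@H](c2coc3ccccc3c2=O)N(c2ccccc2)O1`) likewise shows only a limit, > 60000 nM.

Compound 4 (`CCO[C@H]1C[C@@H](c2coc3ccc(F)cc3c2=O)N(c2ccccc2)O1`) differs from compound 3 by fluoro in place of hydrogen on an aromatic carbon. Within the data shown here, the only measured step, a step that the two limits leave unreadable from compound 2 to compound 3, concerns a saturated ring carbon and offers no size to carry over. Compound 3 differs from compound 1 in several places, so compound 1 with its 9900 nM is only a faint hint that stronger inhibition is possible. A small gain at most is expected, and the estimated step is an at least 1.5-fold lower number from compound 3 to compound 4 (0.17 log units; that floor lies within the scatter). The estimate for compound 4 is 40000 nM, with an expected range of 12000 nM to 80000 nM.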

Compound 4, half-maximal inhibitory concentration: 26400 nM
The estimate for compound 4 lay 1.5-fold (0.18 log units) above the measured number, within the range that was stated.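

In this assay, fluoro on this aromatic carbon turns an unreadable result into a readable one, with an at least 2.2-fold lower number from compound 3 to compound 4 (0.35 log units; beyond the scatter). Compound 3 reads > 60000 nM, which is a limit of the assay and not a number. The true step may be larger, because it starts from such a limit: the limit of > 60000 nM in this assay, at which 2 of the 4 values shown sit.

From the compounds shown here alone, whether chloro, methyl or an amine on this same carbon would lower the number further remains open. Going by these compounds, it is also open whether fluoro would have a similar effect with methoxycarbonyl in place of ethoxy on the saturated ring carbon.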